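A few compounds are considered here, and "the series" means these few. Any claim that something is new, unique, unknown or untested is made for them only; others in the source may bear on it.

Of the compounds shown here, two have been measured in a functional assay on MT4 cells (Homo sapiens) for cytotoxicity, read by MTT assay; a lower number here means that less compound is tolerated, a higher number that more compound is tolerated. Compound 1 (`Cc1cc(C)cc(S(=O)(=O)c2c(C(=O)NCC(N)=O)[nH]c3ccc(Cl)cc23)c1`) gives 45 uM. Compound 2 (`O=C(NN1CCOC1=O)c1[nH]c2ccc(Cl)cc2c1S(=O)(=O)c1ccccc1`) gives > 100 uM, and that value is a limit of the assay, not a number.

Compound 3 (`Cc1cc(C)cc(S(=O)(=O)c2c(C(=O)NN3CCOC3=O)[nH]c3ccc(Cl)cc23)c1`) has not yet been measured. It differs from compound 2 in one place, with 3,5-dimethylphenyl in place of phenyl on a sulfonyl sulfur.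

Among the measured compounds shown here, no measured pair isolates this change, so the expectation is tentative. Compound 1 also carries 3,5-dimethylphenyl and gives 45 uM, although it differs from compound 2 elsewhere as well. A modest move towards less compound being tolerated in this assay is therefore expected, and the estimated step is an at least 1.4-fold lower number from compound 2 to compound 3 (0.15 log units; that floor lies within the scatter). For compound 3 the expected value is 70 uM, with an estimated range from 25 uM to 150 uM.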

Compound 3, half-maximal toxic concentration: 100 uM
Beside the measured number, compound 3's estimate is 1.4-fold (0.15 log units) below it; low and high end bracket the measured number.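

With 3,5-dimethylphenyl on the sulfonyl sulfur in both compounds, the pair of compound 1 and compound 3 isolates the group on the amide-type nitrogen: in this assay, 2-oxo-1,3-oxazolidin-3-yl in place of carbamoylmethyl gives a 2.2-fold higher number from compound 1 to compound 3 (0.35 log units; beyond the scatter). The change from phenyl to 3,5-dimethylphenyl on the sulfonyl sulfur gives a number no higher from compound 2 to compound 3 (the limit leaves the size open). The size of this change cannot be read, because compound 2 stands at a limit rather than a number: the limit of > 100 uM in this assay, at which 1 of the 3 values shown sits.

Still open, on these data alone, is how a single methyl on the phenyl, or a longer chain on the sulfonyl sulfur, would read in this assay. As far as these compounds go, a carboxylic acid in place of carbamoylmethyl on the amide-type nitrogen is equally open.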